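Methoxy in place of phenyl on a long-lived amide

The compounds below may be only part of what the source reports. "The series", "measured", "known", "first", "only" and "open" are said of these compounds alone.

In an ADME assay for pharmacokinetics, read by LC-MS, in phosphate buffer, with a stated time of 120 min, at pH 7.4, tested at 1 uM, in the presence of a further agent that is not named here (a lower number here means that the compound disappears faster, a higher number that the compound lasts longer), compound 1 (`C=C(Cc1ccccc1)C(=O)Nc1ccccc1`) is recorded only as a limit, > 8.53 h, so its half-life has no exact number. Among the compounds with values here, compound 2 (`CN(C)C/C=C/C(=O)Nc1ccccc1`), the only other compound measured, does give a number, 1.93 h. Compound 3 (`C=C(COC)C(=O)Nc1ccccc1`) differs from compound 1 by having methoxy in place of phenyl on a saturated chain carbon bound to a double-bonded chain carbon. Within the data shown here, no measured pair isolates this change, so its effect in this assay remains a matter of judgement. A shorter half-life is expected, and a reading at the limit remains possible. Compound 2 at 1.93 h shows that an amide in this small set can give a measurable number. The expected change is an at least 1.7-fold lower number from compound 1 to compound 3 (0.23 log units; that floor lies within the scatter). For compound 3 the estimated half-life is 5 h, with an expected range of 1.5 h to 15 h.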

Compound 3, half-life: 4.02 h
Estimate against measurement, compound 3: 1.2-fold (0.09 log units) above; measured number inside the range.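

Methoxy in place of phenyl on a saturated chain carbon bound to a double-bonded chain carbon gives a reading with a number in this assay, and the step is an at least 2.1-fold lower number from compound 1 to compound 3 (0.32 log units; beyond the scatter). Within the data shown here, this is the first sign that the group at this position bears on the half-life of the shared core, and that one change here is enough to produce a difference beyond the scatter. Compound 1 is recorded only as a limit, so the step is a floor and its full size remains unknown: the limit of > 8.53 h in this assay, at which 1 of the 3 values shown sits.

The compounds shown leave open whether the shorter half-life follows the arrival of the oxygen or the departure of the ring. An ethyl chain or a hydroxyl on the same saturated chain carbon would help separate the two.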